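Swapping the amine back on a longer chain

The compounds below may be only part of what the source reports. "The series", "measured", "known", "first", "only" and "open" are said of these compounds alone.

For the measured compounds named here, compound 2 `CCN(CC)CCCCOc1ccc(/C=C/C(=O)Nc2ccccc2)cc1OC` gives 1.59 in a physicochemical assay for lipophilicity, using the shake flask method, measured as octanol-water partition, at pH 7.4 (on this read-out higher numbers stand for higher lipophilicity and lower numbers for lower lipophilicity), and the only other measured number, from compound 1 `COc1cc(/C=C/C(=O)Nc2ccccc2)ccc1OCCCN1CCCCC1`, is 1.58, so the two compounds cannot be told apart on this read-out. Going by the values given here, the step of a number 0.01 log units higher from compound 1 to compound 2 (within the scatter) is the single measured comparison, and it replaced one amine by the other without any shift beyond the scatter. Compound 3 `COc1cc(/C=C/C(=O)Nc2ccccc2)ccc1OCCCCN1CCCCC1` carries the reverse exchange, (piperidin-1-yl in place of diethylamino on a saturated chain carbon, four bonds along the chain from an oxygen on an aromatic ring), on a chain one bond longer than in compound 1. Because a number 0.01 log units higher from compound 1 to compound 2 (within the scatter) showed nothing beyond the scatter for the same pair of amines, compound 3 is expected to sit close to compound 2, with a step of about a number 0.06 log units higher from compound 2 to compound 3 (within the scatter). Compound 3 is therefore estimated at 1.65, within a range from 1.25 to 2.05.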

Compound 3, partition coefficient: 1.61
Compound 3: the middle estimate sits 0.04 log units above what was measured, within the range that was stated.
By their numbers in this assay, from the lowest: compounds 1, 2 and 3 (each within the scatter of the next).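

The step of a number 0.02 log units higher from compound 2 to compound 3 (within the scatter) in this assay stays within the scatter, so the exchange between diethylamino and piperidin-1-yl, on a saturated chain carbon, four bonds along the chain from an oxygen on an aromatic ring, leaves these two compounds indistinguishable on this read-out. The comparison with the amine held as piperidin-1-yl is new: the step of a number 0.03 log units higher from compound 1 to compound 3 (within the scatter) for (piperidin-1-yl)methyl in place of piperidin-1-yl is also within the scatter, so this one added chain carbon gives no readable difference either. No supporting evidence bears on these results. Still open, as far as these compounds go, is whether an amine such as morpholine or piperazine would give a step beyond the scatter at this position. For the compounds shown here, a longer chain than the one in compound 3, or a carboxylic acid in place of the amine, also remains to be seen.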